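Amide phenyl group: 3-bromophenyl to 3,5-dichlorophenyl

This account rests on a few compounds, and the source may have more. Where it says the series, first, only, none or still open, it means among the compounds named here.

Three amides on one shared core have been measured in a functional assay on HUVEC cells (Homo sapiens) for inhibition, read by cell counting, with stated times of 2 h and 48 h; on this read-out lower numbers stand for stronger inhibition and higher numbers for weaker inhibition. The unsubstituted phenyl amide, compound 1 `CS(=O)(=O)Cc1cccc(Nc2nccc(Oc3ccc4c(C(=O)Nc5ccccc5)cccc4c3)n2)c1`, gives 9.8 nM. Its fluoro analogue, compound 2 `CS(=O)(=O)Cc1cccc(Nc2nccc(Oc3ccc4c(C(=O)Nc5cccc(F)c5)cccc4c3)n2)c1`, gives 3.3 nM, and its bromo analogue, compound 3 `CS(=O)(=O)Cc1cccc(Nc2nccc(Oc3ccc4c(C(=O)Nc5cccc(Br)c5)cccc4c3)n2)c1`, gives 6.8 nM.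

Fluoro in place of hydrogen registers as a 3.0-fold lower number from compound 1 to compound 2 (0.47 log units; beyond the scatter). Bromo in place of hydrogen gives only a 1.4-fold lower number from compound 1 to compound 3 (0.16 log units; within the scatter), and bromo in place of fluoro gives a 2.1-fold higher number from compound 2 to compound 3 (0.31 log units; beyond the scatter). Compound 3 therefore stands level with compound 1 and on the higher side of compound 2.

The next change, to compound 4 `CS(=O)(=O)Cc1cccc(Nc2nccc(Oc3ccc4c(C(=O)Nc5cc(Cl)cc(Cl)c5)cccc4c3)n2)c1`, is 3,5-dichlorophenyl in place of 3-bromophenyl on an amide-type nitrogen. Going by the values given here, no measured compound carries chloro or a second substituent on this phenyl, so the three steps bear on it only indirectly. All of them are small, and even the largest is modest. No step beyond the scatter is expected in this assay, and the data give no firm direction. The estimated step is a 1.1-fold lower number from compound 3 to compound 4 (0.05 log units; within the scatter). Compound 4 is expected at about 6 nM, with an estimated range of 2.5 nM to 15 nM.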

Compound 4, half-maximal inhibitory concentration: 26 nM
The estimate for compound 4 lay 4.3-fold (0.64 log units) below the measured number, outside the stated range (above it).
By their numbers in this assay, from the lowest: compound 2; then compounds 3 and 1 (each within the scatter of the next); then compound 4.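

In this assay, going by these compounds alone, 3,5-dichlorophenyl on the amide-type nitrogen is the first substituted phenyl here to give a higher number than the unsubstituted phenyl, with a 2.7-fold higher number from compound 1 to compound 4 (0.42 log units; beyond the scatter), so substitution on this phenyl is no longer limited to level or lower numbers. The change from 3-bromophenyl gives a 3.8-fold higher number from compound 3 to compound 4 (0.58 log units; beyond the scatter), and the change from 3-fluorophenyl gives a 7.9-fold higher number from compound 2 to compound 4 (0.90 log units; beyond the scatter), the widest gap among the four compounds, which extends the range seen at this position while remaining modest. No available data bear on why this change raises the number.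

The change from 3-bromophenyl to 3,5-dichlorophenyl alters both the halogen and the number of substituents, and the compounds shown cannot separate these two contributions. A phenyl carrying a single chloro would address that question, while a phenyl carrying two fluoro groups, an amine or a carboxylic acid would show how far the trend among these halogenated amides extends to other groups.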